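A few compounds are considered here, and "the series" means these few. Any claim that something is new, unique, unknown or untested is made for them only; others in the source may bear on it.

Compound 3 `Cc1ccc2[nH]c(=O)c(-c3nc4cc(Br)ccc4[nH]3)cc2c1` is the reference point for this step. In a functional assay on NCI-H460 cells (Homo sapiens) for cytotoxicity, read by MTT assay, with a stated time of 48 h (a lower number here means a stronger inhibitor, a higher number a weaker inhibitor), compound 3 gives only a limit, > 100000 nM, not a number. Compound 1 `O=c1[nH]c2ccccc2cc1-c1nc2cc(Br)ccc2[nH]1` in this assay gives 16800 nM. Among the compounds with values here, the one measured step in the set, an at least 5.9-fold higher number from compound 1 to compound 3 (0.77 log units; beyond the scatter), is a lower bound, since it runs into (the limit of > 100000 nM in this assay, at which 2 of the 3 values shown sit). Compound 2 `COc1ccc2[nH]c(=O)c(-c3nc4ccccc4[nH]3)cc2c1` likewise gives only a limit in this assay, > 100000 nM.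

Compound 4 `COc1ccc2[nH]c(=O)c(-c3nc4cc(Br)ccc4[nH]3)cc2c1` has not been measured in this assay. It differs from compound 3 in one place: methoxy in place of methyl on an aromatic carbon. Within the data shown here, no measured step compares methoxy with methyl. What is known is that compound 3 sits at the limit, and that compound 2, which also carries a methoxy group, sits at the limit as well. Among the measured compounds shown here, with no step pointing to a recovery of potency, compound 4 is expected to remain at or near the limit. Compound 4 is estimated at 100000 nM, with a range of 30000 nM to 300000 nM, which means an expected step of a number no higher from compound 3 to compound 4 (the limit leaves the size open), none beyond the scatter.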

Compound 4, half-maximal inhibitory concentration: > 100000 nM
Compound 4 gave a limit, no number; the forecaster's own chance of this, stated with the estimate: 70%; the middle value lies on the limit itself.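

In this assay, compound 4 gives > 100000 nM, which is a limit and not a number. Methoxy in place of hydrogen on this aromatic carbon gives an at least 5.9-fold higher number from compound 1 to compound 4 (0.77 log units; beyond the scatter), a lower bound, so the loss seen with methyl now also appears with a second group at this position. The steps to compound 4 from compound 3 and from compound 2 cannot be read, and the series now stands as follows: the limit of > 100000 nM in this assay, at which 3 of the 4 values shown sit.

Methoxy and methyl cannot be ranked against each other at this position, and the effect of bromo on the methoxy compounds stays unreadable. From the compounds shown here alone, it also remains open whether fluoro, hydroxyl or an amine on this carbon would give a measurable value, as hydrogen does in compound 1 with 16800 nM.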